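The source may report more compounds than this note shows. Statements on the series, on what has been measured and on what is new or still open speak of the compounds shown alone.

Of the compounds shown here, three built on one shared core have been measured so far. Compound 1 `CN1CCCC(NS(=O)(=O)c2ccccc2Nc2cc(-c3ccc4ccn(C)c4c3)c3nccnc3c2)C1` gives 59 nM in an assay for inhibition of 6-phosphofructo-2-kinase/fructose-2,6-bisphosphatase 3 (Homo sapiens), read by ADP-Glo, with a stated time of 2 h; a lower number here means a stronger inhibitor, a higher number a weaker inhibitor. Compound 2 `CN(Cc1cncnc1)S(=O)(=O)c1ccccc1Nc1cc(-c2ccc3ccn(C)c3c2)c2nccnc2c1` gives 62 nM in this assay. Compound 3 `Cn1ccc2ccc(-c3cc(Nc4cnccc4C(=O)NCc4cncnc4)cc4nccnc34)cc21` gives 106 nM in this assay. Compound 3 thus carries the highest of the three numbers, but its gaps to compound 2 and to compound 1 both lie within the scatter, so the three cannot be told apart with confidence.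

Compound 4 `Cn1ccc2ccc(-c3cc(Nc4cnccc4C(=O)NC4CCNC(=O)C4)cc4nccnc34)cc21` is compound 3 with a single change: 2-oxopiperidin-4-yl in place of (pyrimidin-5-yl)methyl on an amide-type nitrogen. One measured step speaks to this kind of swap: a 1.1-fold higher number from compound 1 to compound 2 (0.02 log units; within the scatter), where (1-methylpiperidin-3-yl)amino gave way to methyl((pyrimidin-5-yl)methyl)amino and the number hardly moved. The change from compound 3 to compound 4 runs roughly the other way, trading (pyrimidin-5-yl)methyl for 2-oxopiperidin-4-yl, though on an amide-type nitrogen rather than a sulfonyl sulfur, so the guide is loose. On that basis the expectation is no step beyond the scatter, a 1.0-fold higher number from compound 3 to compound 4 (0.02 log units; within the scatter). Compound 4 is therefore estimated at 110 nM in this assay, with a range from 45 nM to 270 nM.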

Compound 4, half-maximal inhibitory concentration: 69 nM
Compound 4: middle estimate off by 1.6-fold (0.20 log units), on the high side; measured number inside the range.
By their numbers in this assay, from the lowest: compounds 1, 2, 4 and 3 (each within the scatter of the next).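

On the amide-type nitrogen, the aromatic (pyrimidin-5-yl)methyl group gives way to the non-aromatic 2-oxopiperidin-4-yl group with a 1.5-fold lower number from compound 3 to compound 4 (0.19 log units; within the scatter) in this assay and this gives the series a direct reading at this place. The two groups have the same count of heavy atoms but differ in ring type and in their hydrogen-bond donors and acceptors, and this pair shows that such a swap at this place need not carry the number beyond the scatter, although a single pair sets no general rule. Nothing available explains why these two groups read alike.

Still open, from the compounds shown here alone, is how much of either ring is needed on this nitrogen: a plain cyclohexyl ring, a piperidine ring with a free amine in place of the ring carbonyl, an open alkyl chain or a group ending in a carboxylic acid would each test a different part of the question. Also open, going by these compounds, is whether 2-oxopiperidin-4-yl would read the same way on the sulfonyl sulfur that compound 1 and compound 2 carry.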